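Series notes: chloro-to-fluoro swap and acid dissociation

A few compounds are considered here, and "the series" means these few. Any claim that something is new, unique, unknown or untested is made for them only; others in the source may bear on it.

Measured compounds in a physicochemical assay for acid dissociation:
compound 1 `O=[N+]([O-])c1cccc(NS(=O)(=O)c2ccc(F)cc2)c1` gives 7.85
compound 2 `O=[N+]([O-])c1cccc(NS(=O)(=O)c2ccc(Cl)cc2)c1` gives 7.51
compound 3 `O=[N+]([O-])c1ccc(S(=O)(=O)Nc2ccc(Cl)cc2)cc1` gives 6.24

Compound 2 and compound 1 share a core and differ by fluoro in place of chloro on an aromatic carbon, which gives the step of a number 0.34 log units higher from compound 2 to compound 1 (beyond the scatter). Compound 3 holds the same atoms as compound 2, joined differently, and the difference between the two cores is not broken down here. In this assay compound 3 stands lowest of the three measured numbers. Compound 4 `O=[N+]([O-])c1ccc(S(=O)(=O)Nc2ccc(F)cc2)cc1` is not yet measured and differs from compound 3 by fluoro in place of chloro on an aromatic carbon, the same change as between compound 2 and compound 1, at a place described in the same words. For the measured compounds named here, the step is expected to come out as a number 0.34 log units higher from compound 3 to compound 4 (beyond the scatter), close to the earlier one, because the single precedent is a number 0.34 log units higher from compound 2 to compound 1 (beyond the scatter). For compound 4 the estimate is 6.58. The expected lower end for compound 4 is 6.3. The expected upper end for compound 4 is 6.9.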

Compound 4, acid dissociation constant: 6.45
Compound 4: middle estimate off by 0.13 log units, on the high side; low and high end bracket the measured number.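

In this assay fluoro in place of chloro on an aromatic carbon gives a number 0.21 log units higher from compound 3 to compound 4 (within the scatter) on the second core, set against a number 0.34 log units higher from compound 2 to compound 1 (beyond the scatter) on the first. The printed numbers rise on both cores, but the new step does not separate from the scatter, so a real shift on the core of compound 3 is not shown, and neither is a difference between the cores. Two pairs support no rule for the series, and no measurement at hand bears on the size of either step.

Open, as far as these compounds go, is how a group other than these two halogens, such as methoxy or an amine, would read on the same aromatic carbon in this assay. Also open, from the compounds shown here alone, is whether the step would hold on a third core.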